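Bromo and Aryl Quinolinone Amides Against KYSE-410 Cells

The source may hold more compounds than are shown below. What is called first, only, known or untested is meant among the compounds shown, and "the series" means these compounds.

Compound 1, `O=C(Nc1ccc(F)cc1)c1cc(=O)[nH]c2cc(Br)ccc12`: in a functional assay on KYSE-410 cells (Homo sapiens) for antiproliferative activity, read by MTT assay, with a stated time of 72 h (on this read-out higher numbers stand for weaker inhibition and lower numbers for stronger inhibition), compound 1 gives only a limit, > 20000 nM.
Compound 2, `CC(C)(C)c1ccc(NC(=O)c2cc(=O)[nH]c3cc(Br)ccc23)cc1`: in this assay compound 2 gives only a limit, > 20000 nM.
Compound 3, `CC(C)(C)c1ccc(-c2ccc3c(C(=O)Nc4cccc(F)c4)cc(=O)[nH]c3c2)cc1`: in this assay compound 3 gives only a limit, > 20000 nM.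

Compounds 1 and 2 share one core and differ in a single place: fluoro in place of tert-butyl on an aromatic carbon. The step that the two limits leave unreadable from compound 2 to compound 1 cannot be sized, because both compounds sit at the limit of > 20000 nM in this assay, at which 3 of the 3 values shown sit. Compound 3 carries a different core; the difference between the two cores is not broken down here. Its value also sits at the limit, so all three measured compounds show no inhibition that the assay can quantify.

Compound 4, `O=C(Nc1cccc(F)c1)c1cc(=O)[nH]c2cc(-c3ccc(F)cc3)ccc12`, has not yet been measured in this assay. It differs from compound 3 as fluoro in place of tert-butyl on an aromatic carbon, the same change already seen between compound 2 and compound 1, at the same place in both pairs. Since that earlier change left both compounds at the limit, and since compound 3 itself sits at the limit of > 20000 nM in this assay, at which 3 of the 3 values shown sit, there is nothing in the measured set to suggest that this change by itself turns an inactive compound into an active one. The step from compound 3 to compound 4 is therefore expected to be a step that the limit leaves unreadable from compound 3 to compound 4. Compound 4 is estimated at 25000 nM, with the most likely outcome being that the assay again reports only a limit.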

Compound 4, half-maximal inhibitory concentration: 10300 nM
Beside the measured number, compound 4's estimate is 2.4-fold (0.39 log units) above it; low and high end bracket the measured number.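

Fluoro in place of tert-butyl on an aromatic carbon, read as 4-(tert-butyl)phenyl to 4-fluorophenyl, gives in this assay an at least 1.9-fold lower number from compound 3 to compound 4 (0.28 log units; that floor lies within the scatter), so on this core the change goes with a measured number for compound 4, while the guaranteed size of the step does not clear the usual scatter. The same change on the bromo core cannot be read, because compound 2 and compound 1 both stay at the limit: the limit of > 20000 nM in this assay, at which 3 of the 4 values shown sit. The series therefore offers no two step sizes to set side by side, and the data show neither that the change carries over from one core to the other nor that it fails to, since a single step with only a floor on one core makes no pattern.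

The compounds shown leave open whether a group other than fluoro or tert-butyl on that aromatic carbon, such as an amine or a carboxylic acid, would give a different number on the core of compound 4. They also leave open whether an amine in place of the bromo group on the core of compound 1 would give a measured number at all in this assay.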